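Shifting a Carbonyl Along the Side Chain of Compound 3

The source may report more compounds than this note shows. Statements on the series, on what has been measured and on what is new or still open speak of the compounds shown alone.

Three compounds sharing one core have numbers in a functional assay on HEL cells (Homo sapiens) (on this read-out lower numbers stand for higher toxicity in this test and higher numbers for lower toxicity in this test), so far. Compound 1 (`Cc1cn([C@@H]2O[C@H](CO[Si](C)(C)C(C)(C)C)[C@@]3(OS(=O)(=O)C=C3NCC(N)=O)[C@H]2O[Si](C)(C)C(C)(C)C)c(=O)n(C)c1=O`) gives 13500 nM there, compound 2 (`C=C(C)C(=O)NC(=O)NC1=CS(=O)(=O)O[C@@]12[C@@H](CO[Si](C)(C)C(C)(C)C)O[C@@H](n1cc(C)c(=O)n(C)c1=O)[C@@H]2O[Si](C)(C)C(C)(C)C`) gives 1200 nM and compound 3 (`COC(=O)CC(=O)NC1=CS(=O)(=O)O[C@@]12[C@@H](CO[Si](C)(C)C(C)(C)C)O[C@@H](n1cc(C)c(=O)n(C)c1=O)[C@@H]2O[Si](C)(C)C(C)(C)C`) gives 29000 nM as the highest number of the three. Compound 4 (`COC(=O)C(=O)CNC1=CS(=O)(=O)O[C@@]12[C@@H](CO[Si](C)(C)C(C)(C)C)O[C@@H](n1cc(C)c(=O)n(C)c1=O)[C@@H]2O[Si](C)(C)C(C)(C)C`) has the same atoms as compound 3, joined differently: ((methoxycarbonyl)carbonyl)methyl in place of ((methoxycarbonyl)methyl)carbonyl on an amine nitrogen with ((methoxycarbonyl)carbonyl)methyl in place of ((methoxycarbonyl)methyl)carbonyl on an amine nitrogen.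

Among the compounds with values here, no measured step makes this exact change, but all three alter the group on that nitrogen. The closest guide is a 2.1-fold higher number from compound 1 to compound 3 (0.33 log units; beyond the scatter) as carbamoylmethyl gives way to ((methoxycarbonyl)methyl)carbonyl, since compound 4, like compound 1, carries a group named as a substituted methyl there. The other two steps, an 11-fold lower number from compound 1 to compound 2 (1.05 log units; beyond the scatter) and a 24-fold higher number from compound 2 to compound 3 (1.38 log units; beyond the scatter) both involve the ((1-methylethenyl)carbonyl)carbamoyl of compound 2, which compound 4 lacks, so they mainly warn that this position can move the number widely. A modest step towards a lower number is therefore expected, with a 2.1-fold lower number from compound 3 to compound 4 (0.32 log units; beyond the scatter) as the estimate in this assay and no certainty about its direction. Compound 4 is estimated at 14000 nM with an expected range from 4000 nM to 40000 nM in this read-out.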

Compound 4, half-maximal cytotoxic concentration: > 200000 nM
Compound 4 gave a limit, no number; the forecaster's own chance of this, stated with the estimate: 5%; at least 14-fold (1.15 log units) between middle value and limit.
By their numbers in this assay, from the lowest: compound 2; then compound 1; then compound 3. At a limit, above all of these: compound 4.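

In this assay compound 4 gives a limit and not a number: the limit of > 200000 nM in this assay, at which 1 of the 4 values shown sits. Rejoining the same atoms, with ((methoxycarbonyl)carbonyl)methyl on the amine nitrogen in place of ((methoxycarbonyl)methyl)carbonyl, gives an at least 6.8-fold higher number from compound 3 to compound 4 (0.83 log units; beyond the scatter), so this position responds strongly even when the counts of atoms, donors and acceptors stay the same, which the earlier steps, all changing the composition of the group, could not show. The other comparisons give an at least 14-fold higher number from compound 1 to compound 4 (1.17 log units; beyond the scatter) and an at least 160-fold higher number from compound 2 to compound 4 (2.22 log units; beyond the scatter); compound 1 also carries a group named as a substituted methyl on that nitrogen, yet it sits well below compound 4, so that form of attachment alone does not go with the limit.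

The compounds shown leave open how far beyond the limit compound 4 lies, so the true size of all three steps remains unknown. They also leave open whether the high reading survives when the methoxycarbonyl end of the ((methoxycarbonyl)carbonyl)methyl group gives way to a carboxylic acid, or when a longer chain carries it on the amine nitrogen.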